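This account rests on a few compounds, and the source may have more. Where it says the series, first, only, none or still open, it means among the compounds named here.

Measured so far:

compound 1 `Cc1cc(C)cc(S(=O)(=O)n2c(SCC(=O)Nc3ccccc3S(N)(=O)=O)nc3ccccc32)c1`: 25000 nM
compound 2 `Cc1cc(C)cc(S(=O)(=O)n2c(OCC(=O)Nc3ccccc3Br)nc3ccccc32)c1`: > 243000 nM (a limit of the assay, not a number)
compound 3 `COC(=O)c1ccc(NC(=O)COc2nc3ccccc3n2S(=O)(=O)c2cc(C)cc(C)c2)c(Cl)c1`: 119000 nM

In an ADME assay on MT4 cells (Homo sapiens) for cytotoxicity, read by MTT assay, with a stated time of 5 days (a lower number here means that less compound is tolerated, a higher number that more compound is tolerated), compound 3 gives 119000 nM, the higher of the two actual numbers, and clearly separated from compound 1 at 25000 nM. Compound 2 stands at > 243000 nM, which is a limit.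

Compound 4 `Cc1cc(C)cc(S(=O)(=O)n2c(OCC(=O)Nc3ccc(S(N)(=O)=O)cc3Cl)nc3ccccc32)c1` has not yet been measured. It differs from compound 3 in one place: sulfamoyl in place of methoxycarbonyl on an aromatic carbon, meta to a chloro group and para to a large group (sulfamoyl in place of methoxycarbonyl on an aromatic carbon).

Among the measured compounds shown here, one measured step concerns this same ring. Going to the 2-chloro-4-(methoxycarbonyl)phenyl group gave an at least 2.0-fold lower number from compound 2 to compound 3 (0.31 log units; beyond the scatter), so a change here can move the number beyond the scatter. For the measured compounds named here, compound 1 is the only measured compound with a sulfamoyl group, and it gives 25000 nM, but it also differs from compound 3 elsewhere. This points to a modest move towards a lower number, although a change within the scatter remains possible.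

The expected step is a 2.0-fold lower number from compound 3 to compound 4 (0.30 log units; within the scatter). The estimate for compound 4 is 60000 nM. The expected range runs from 20000 nM to 180000 nM.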

Compound 4, half-maximal cytotoxic concentration: > 227000 nM
Compound 4 was reported as a limit (the forecaster's own chance of this, stated with the estimate: 10%); middle value at least 3.7-fold (0.57 log units) from the limit.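

In this assay compound 4 gives > 227000 nM, which is a limit of the assay and not a number. The swap of methoxycarbonyl for sulfamoyl, two groups with the same count of heavy atoms, gives an at least 1.9-fold higher number from compound 3 to compound 4 (0.28 log units; that floor lies within the scatter), so a fall in the number at this position is excluded, while a rise beyond the scatter is not established. The earlier compounds shown here showed only that going to the 2-chloro-4-(methoxycarbonyl)phenyl group lowered the number, and compound 4 now shows that a group at this position on the chlorinated ring does not by itself bring that lower number, with compound 3 remaining the one that stands lower.

On these data alone, the step between compound 2 and compound 4 cannot be read, since both are limits, so the 2-bromophenyl and 2-chloro-4-sulfamoylphenyl groups cannot be ranked against each other, and the true value of compound 4 stays unknown. The compounds shown also leave open how a carboxylic acid or an amine in this same place on the ring would read in this assay.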